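The compounds below may be only part of what the source reports. "The series", "measured", "known", "first", "only" and "open" are said of these compounds alone.

Compound 3 `O=C1c2ccccc2N(Cc2ccc(Cl)c(Cl)c2)S(=O)(=O)N1Cc1ccccc1` gives 56000 nM in a functional assay on MRC5 cells (Homo sapiens) (on this read-out higher numbers stand for lower toxicity in this test and lower numbers for higher toxicity in this test), the lowest of the two numbers shown, with compound 2 `O=C1c2ccccc2N(Cc2cccc(Cl)c2)S(=O)(=O)N1Cc1ccccc1` nearest at 60000 nM, the pair separated by a 1.1-fold lower number from compound 2 to compound 3 (0.03 log units; within the scatter). Compound 1 `O=C1c2ccccc2N(Cc2ccc([N+](=O)[O-])cc2)S(=O)(=O)N1Cc1ccccc1` reaches only the limit of the test, > 59000 nM, in this assay. From there the step of an at least 1.0-fold lower number from compound 1 to compound 3 (0.02 log units; that floor lies within the scatter) is read against that floor, and the step that the limit leaves unreadable from compound 1 to compound 2. Compound 4 `O=C1c2ccccc2N(CCCc2ccccc2)S(=O)(=O)N1Cc1ccccc1` differs from compound 3 in that (phenethyl in place of 3,4-dichlorophenyl on a saturated chain carbon bound to a sulfonamide nitrogen in a ring). The measured steps at this position each exchanged groups on the aromatic ring and none moved the number beyond the scatter, so the expected step of a 1.0-fold lower number from compound 3 to compound 4 (0.01 log units; within the scatter) in this assay is none beyond the scatter. Compound 4 is estimated at 55000 nM, between 25000 nM and 80000 nM.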

Compound 4, half-maximal cytotoxic concentration: > 57000 nM
Compound 4: a limit, no number (the forecaster's own chance of this, stated with the estimate: 40%); at least 1.0-fold (0.01 log units) between middle value and limit.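

In this assay compound 4 gives only a limit, not a number: the limit of > 57000 nM in this assay, at which 1 of the 4 values shown sits. Going from 3,4-dichlorobenzyl to 3-phenylpropyl, the first change here to alter the chain itself and not only the groups on the aromatic ring, gives an at least 1.0-fold higher number from compound 3 to compound 4 (0.00 log units; that floor lies within the scatter), a floor that leaves the true size of the step unknown. The steps from compound 1 and from compound 2 to compound 4 cannot be read. From the compounds shown here alone, it remains open whether an amine or a carboxylic acid at this position, or a chain longer than 3-phenylpropyl, would give a readable number in this assay.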